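A few compounds are considered here, and "the series" means these few. Any claim that something is new, unique, unknown or untested is made for them only; others in the source may bear on it.

Compounds measured so far:

Compound 1, `Cc1cc(-c2ccccc2)n(/C(N)=N/S(=O)(=O)c2cc(C)c(Cl)cc2SCc2cccc(C(F)(F)F)c2)n1`, in a functional assay on HeLa cells (Homo sapiens) for cytotoxicity, read by MTT assay, with a stated time of 72 h; a lower number here means a stronger inhibitor, a higher number a weaker inhibitor: 98000 nM
Compound 2, `Cc1cc(S(=O)(=O)/N=C(\N)n2nccc2-c2ccccc2)c(SCc2ccccc2Cl)cc1Cl`, in this assay: 19000 nM

Of these two, compound 2 gives the lower number in this assay with 19000 nM, while compound 1 gives 98000 nM, a gap that lies beyond the usual scatter; the two compounds differ in more than one place, so nothing beyond their two values can be read from the pair.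

Compound 3, `Cc1cc(-c2ccccc2)n(/C(N)=N/S(=O)(=O)c2cc(C)c(Cl)cc2SCc2ccccc2Cl)n1`, has not yet been measured. It follows from compound 2 by a single change: methyl in place of hydrogen on an aromatic carbon. Among the compounds with values here, the change is small, adding one carbon and no ring, donor, acceptor or charge, and no measured pair shows what such a change does here.

Within the data shown here, with no comparable step on record, the expectation for compound 3 is a step from compound 2 of a 1.3-fold higher number from compound 2 to compound 3 (0.12 log units; within the scatter), that is, little movement beyond the scatter in either direction. Compound 3 is therefore estimated at 25000 nM, with a range from 8000 nM to 80000 nM.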

Compound 3, half-maximal inhibitory concentration: 270000 nM
The estimate for compound 3 lay 11-fold (1.03 log units) below the measured number, outside the stated range (above it).
By their numbers in this assay, from the lowest: compound 2; then compound 1; then compound 3.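

The methyl is a single carbon, yet this position on the five-membered aromatic ring with 2 nitrogen, next to the ring nitrogen, turns out to be far from indifferent: in this assay methyl in place of hydrogen gives a 14-fold higher number from compound 2 to compound 3 (1.15 log units; beyond the scatter) and takes the series to a weaker reading, a large step beyond the scatter. Within the data shown here, the same compound 3 also supplies the first reading of the group on the saturated chain carbon bound to a sulfur, where 2-chlorophenyl in place of 3-(trifluoromethyl)phenyl gives a 2.8-fold higher number from compound 1 to compound 3 (0.44 log units; beyond the scatter) on the methyl-bearing core, so that this change too moves the number, though only modestly. Nothing measured here offers an explanation for either step.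

The compounds shown leave open whether the methyl step would be of similar size with 3-(trifluoromethyl)phenyl on the chain carbon, since that group appears here only together with the methyl. They also leave open how a longer chain such as ethyl, or an amine, would read on the same ring carbon.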